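Trifluoromethyl to methyl on the fused carbocycle

The source may hold more compounds than are shown below. What is called first, only, known or untested is meant among the compounds shown, and "the series" means these compounds.

Measured in a functional assay on the whole organism (strain Sprague-Dawley) for inhibition, with Rattus norvegicus as the target; a lower number here means that less compound is needed, a higher number that more compound is needed for the effect:
compound 1 `O=c1c(-c2nn[nH]n2)c[nH]c2c(F)ccc(F)c12` — a limit of the assay only, > 0.156 mg/kg
compound 2 `COc1ccc(OC)c2ncc(-c3nn[nH]n3)cc12` — 5 mg/kg
compound 3 `O=c1c(-c2nn[nH]n2)c[nH]c2c(C(F)(F)F)cccc12` — 0.156 mg/kg

Compound 3 stands at the lowest of the two numbers in this assay. Compound 2 sits at a markedly higher number, and that gap is beyond the scatter. Compound 1 is recorded at the limit of > 0.156 mg/kg in this assay, at which 1 of the 3 values shown sits, and so gives no number to rank against the others.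

The next compound in the series, compound 4 `Cc1cccc2c(=O)c(-c3nn[nH]n3)c[nH]c12`, differs from compound 3 by methyl in place of trifluoromethyl on an aromatic carbon. Within the data shown here, no measured pair in this set carries that swap, so no step of known size can be pointed to. The working expectation is a modest drift toward a higher number for compound 4 relative to compound 3, expressed as an estimated step of a 1.9-fold higher number from compound 3 to compound 4 (0.28 log units; within the scatter), which may yet fall within the scatter. On that basis compound 4 is expected to give about 0.3 mg/kg in this assay, with a likely range from 0.1 mg/kg to 1.25 mg/kg.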

Compound 4, minimum effective dose: > 5 mg/kg
Compound 4 ended at the assay's limit; the forecaster's own chance of this, stated with the estimate: 20%; at least 16-fold (1.22 log units) between middle value and limit.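

In this assay, the change of trifluoromethyl to methyl on this aromatic carbon gives an at least 32-fold higher number from compound 3 to compound 4 (1.50 log units; beyond the scatter). Among these compounds, this is the first comparison that differs in one place, and it shows that the group on this carbon matters strongly with the rest of the structure unchanged; compound 1 and compound 2 each differ from compound 3 in more than one place and could not show this. Compound 4 is recorded at a limit of the assay and not at a number, so the step gives only the least size of the change: the limit of > 5 mg/kg in this assay, at which 1 of the 4 values shown sits.

Only trifluoromethyl and methyl can be compared directly on this aromatic carbon. From the compounds shown here alone, what a chlorine atom, a nitrile or a longer chain would give there remains open.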